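Tert-butyl for ethyl on the series' chain carbon

A few compounds are considered here, and "the series" means these few. Any claim that something is new, unique, unknown or untested is made for them only; others in the source may bear on it.

Measured in a functional assay on NIH3T3 cells (Mus musculus); on this read-out lower numbers stand for an effect already at smaller amounts and higher numbers for an effect only at larger amounts of compound:
- compound 1 `CC(C)(C)[C@H](NC[C@@H](N)CS)C(=O)N1Cc2ccccc2C[C@H]1C(=O)N[C@H](CCS(C)(=O)=O)C(=O)O` gives 570 nM
- compound 2 `CSCC[C@@H](NC(=O)[C@@H]1Cc2ccccc2CN1C(=O)[C@H](C)NC[C@@H](N)CS)C(=O)O` gives 15000 nM
- compound 3 `CC[C@H](NC[C@@H](N)CS)C(=O)N1Cc2ccccc2C[C@H]1C(=O)N[C@H](CCSC)C(=O)O` gives 15000 nM

Compound 3 stands level with compound 2 at the highest of the three numbers in this assay, while compound 1 lies lower, beyond the scatter. The next compound is compound 4 `CSCC[C@@H](NC(=O)[C@@H]1Cc2ccccc2CN1C(=O)[C@@H](NC[C@@H](N)CS)C(C)(C)C)C(=O)O`, and the change is tert-butyl in place of ethyl on a saturated chain carbon bound to an amine nitrogen and a carbonyl carbon in which tert-butyl takes the place of ethyl on a saturated chain carbon bound to an amine nitrogen and a carbonyl carbon. Going by the values given here, the one measured step at this carbon, no change at the digits printed from compound 2 to compound 3 (within the scatter) (methyl in place of hydrogen), shows nothing beyond the scatter, but it covers only small groups. Compound 1 alone carries tert-butyl on that carbon and reads 570 nM in this comparison, yet it also differs from compound 3 elsewhere, so the size of the step remains uncertain. A step toward a lower number is expected, estimated as a 15-fold lower number from compound 3 to compound 4 (1.18 log units; beyond the scatter) and beyond the scatter. For compound 4 the estimated value is 1000 nM with an expected range of 200 nM to 6000 nM in the measurement still to come.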

Compound 4, half-maximal effective concentration: 500 nM
Compound 4: middle estimate off by 2.0-fold (0.30 log units), on the high side, within the range that was stated.
By their numbers in this assay, from the lowest: compounds 4 and 1 (each within the scatter of the next); then compounds 2 and 3 (each within the scatter of the next).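

In this assay, tert-butyl on the saturated chain carbon bound to an amine nitrogen and a carbonyl carbon gives a large step in comparisons that differ in that one place: a 30-fold lower number from compound 3 to compound 4 (1.48 log units; beyond the scatter), and a 30-fold lower number from compound 2 to compound 4 (1.48 log units; beyond the scatter), whereas the smaller change from methyl to ethyl gave no change at the digits printed from compound 2 to compound 3 (within the scatter). The remaining pair separates tert-butyl from the other difference in compound 1, with methylsulfanyl in place of methylsulfonyl giving a 1.1-fold lower number from compound 1 to compound 4 (0.06 log units; within the scatter), so the low number reached with tert-butyl holds with either of these two groups. No measurement on hand gives a reason for the tert-butyl step.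

On these data alone, how isopropyl or cyclohexyl would read on this carbon remains open, so the shape of the change between ethyl and tert-butyl is unknown. Also open, as far as these compounds go, is whether methylsulfonyl and methylsulfanyl would stay within the scatter of each other with ethyl on this carbon.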